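The compounds below may be only part of what the source reports. "The series", "measured", "known", "first", "only" and "open" are said of these compounds alone.

Measured so far:
- compound 1 `CCNC(=O)Nc1cccc2c1CN(C)CC2c1ccccc1`: 54 mg/kg
- compound 2 `CCCNC(=O)Nc1cccc2c1CN(C)CC2c1ccccc1`: > 80 mg/kg
- compound 3 `CCNCCC(=O)Nc1cccc2c1CN(C)CC2c1ccccc1`: > 160 mg/kg

In a functional assay on the whole organism for inhibition, with Mus musculus as the target (a lower number here means that less compound is needed, a higher number that more compound is needed for the effect), compound 1 gives 54 mg/kg. For compound 2 the value > 80 mg/kg is a limit of the assay, not a number. For compound 3 the value > 160 mg/kg is likewise a limit. The change methyl in place of hydrogen on a saturated chain carbon, two bonds along the chain from an amide-type nitrogen made an at least 1.4-fold higher number from compound 1 to compound 2 (0.17 log units; that floor lies within the scatter). The change (2-(ethylamino)ethyl in place of ethylamino on a carbonyl carbon), which is also how the cores of the two pairs differ, made an at least 2.9-fold higher number from compound 1 to compound 3 (0.47 log units; beyond the scatter). The step that the two limits leave unreadable from compound 2 to compound 3 is unreadable because the limit of > 160 mg/kg in this assay, at which 1 of the 3 values shown sits, and the limit of > 80 mg/kg in this assay, at which 1 of the 3 values shown sits, cap both values.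

Compound 4 `CC(C)NCCC(=O)Nc1cccc2c1CN(C)CC2c1ccccc1` is not yet measured; it carries methyl in place of hydrogen on a saturated chain carbon bound to an amine nitrogen and a saturated chain carbon. This is the same kind of change as from compound 1 to compound 2, though the place differs: a saturated chain carbon bound to an amine nitrogen and a saturated chain carbon, rather than one two bonds along the chain from an amide-type nitrogen. In this assay the step is expected to be a step that the limit leaves unreadable from compound 3 to compound 4, resting on an at least 1.4-fold higher number from compound 1 to compound 2 (0.17 log units; that floor lies within the scatter) and on compound 3 already standing at a limit. Compound 4 is estimated at 250 mg/kg, between 120 mg/kg and 600 mg/kg, most likely again reported only as a limit.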

Compound 4, dose for half-maximal effect: about 125 mg/kg
The estimate for compound 4 lay 2.0-fold (0.30 log units) above the measured number; measured number inside the range.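

In this assay, methyl in place of hydrogen on a saturated chain carbon bound to an amine nitrogen and a saturated chain carbon gives an at least 1.2-fold lower number from compound 3 to compound 4 (0.10 log units; that floor lies within the scatter), while the exchange of the group on the carbonyl carbon gives a 2.3-fold higher number from compound 1 to compound 4 (0.36 log units; beyond the scatter). Set beside the same change on the other core, the result gives no readable size or direction that carries over: the same change on two cores in this assay, an at least 1.4-fold higher number (0.17 log units; that floor lies within the scatter) from compound 1 to compound 2 and an at least 1.2-fold lower number (0.10 log units; that floor lies within the scatter) from compound 3 to compound 4; the limit leaves it open whether they differ. It shows neither that the change transfers between the two cores nor that it fails to, and the step from compound 2 to compound 4 cannot be read.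

From the compounds shown here alone, with compound 2 and compound 3 known only as limits, the true size of the change on either core stays open. Also open, going by these compounds, is how tert-butyl in place of isopropyl would read on the core of compound 4.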